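Methyl on the Core Beside Two Different Chains

The source may hold more compounds than are shown below. What is called first, only, known or untested is meant among the compounds shown, and "the series" means these compounds.

Three compounds were measured in a functional assay on COLO 205 cells (Homo sapiens) for cytotoxicity, read by MTT assay, with a stated time of 24 h; on this read-out higher numbers stand for weaker inhibition and lower numbers for stronger inhibition:
compound 1, `O=c1c2c(C(F)(F)F)cc(-c3ccccc3)nc2ncn1Cc1cn(CCC(F)(F)C(F)(F)C(F)(F)C(F)(F)C(F)(F)C(F)(F)C(F)(F)C(F)(F)F)nn1`, 163 ug/mL
compound 2, `CCCCCCCCCCn1cc(Cn2cnc3nc(-c4ccccc4)cc(C(F)(F)F)c3c2=O)nn1`, 19.3 ug/mL
compound 3, `Cc1nc2nc(-c3ccccc3)cc(C(F)(F)F)c2c(=O)n1Cc1cn(CCC(F)(F)C(F)(F)C(F)(F)C(F)(F)C(F)(F)C(F)(F)C(F)(F)C(F)(F)F)nn1`, a value that is only a limit, > 200 ug/mL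

Compound 2 gives the lowest of the two numbers, and compound 1 stands well above it; how the cores of compound 1 and compound 2 differ is not broken down here. Compound 3 arises from compound 1 by methyl in place of hydrogen on an aromatic carbon, and that step, an at least 1.2-fold higher number from compound 1 to compound 3 (0.08 log units; that floor lies within the scatter), ends at the limit (the limit of > 200 ug/mL in this assay, at which 1 of the 3 values shown sits). Compound 4, `CCCCCCCCCCn1cc(Cn2c(C)nc3nc(-c4ccccc4)cc(C(F)(F)F)c3c2=O)nn1`, is not yet measured; it arises from compound 2 by the same change, (methyl in place of hydrogen on an aromatic carbon). Compound 4 is expected at 32 ug/mL, between 12 ug/mL and 90 ug/mL. The expected step of a 1.7-fold higher number from compound 2 to compound 4 (0.22 log units; within the scatter) rests on the step from compound 1, an at least 1.2-fold higher number from compound 1 to compound 3 (0.08 log units; that floor lies within the scatter), which adds the methyl without a clear gain.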

Compound 4, half-maximal inhibitory concentration: 15 ug/mL
Beside the measured number, compound 4's estimate is 2.1-fold (0.33 log units) above it; measured number inside the range.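

In this assay, methyl in place of hydrogen on an aromatic carbon gives a 1.3-fold lower number from compound 2 to compound 4 (0.11 log units; within the scatter), so on this core the change leaves the number within the scatter. Neither core shows a clear gain from the methyl, but the two steps cannot be fully compared: the same change on two cores in this assay, an at least 1.2-fold higher number (0.08 log units; that floor lies within the scatter) from compound 1 to compound 3 and a 1.3-fold lower number (0.11 log units; within the scatter) from compound 2 to compound 4; the limit leaves it open whether they differ Compound 3 stands at a limit, so its step gives only a floor and not a size: the limit of > 200 ug/mL in this assay, at which 1 of the 4 values shown sits.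

The compounds shown leave open whether a larger group or another kind of group at this place, such as an ethyl, an amine or a methoxy, would move the number beyond the scatter on either core. They also leave open how a shorter chain would behave with or without the methyl.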